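Replacing fluoro with acetyl on a shared imidazopyrazine scaffold

The source may report more compounds than this note shows. Statements on the series, on what has been measured and on what is new or still open speak of the compounds shown alone.

Of the compounds shown here, three have been measured in a functional assay on U-251 cells (Homo sapiens) for inhibition, read by sulforhodamine B assay, with a stated time of 48 h, tested at 10 uM; a higher number here means more inhibition at the concentration tested (going by the name of the read-out), a lower number less inhibition. Compound 1, `c1ccc(-c2cn3ccnc3c(-c3ccc4ncn(C5CCCCC5)c4c3)n2)cc1`, gives 37.3%. Compound 2, `O=Cc1ccc(-c2cn3ccnc3c(-c3ccc4ncn(C5CCCCC5)c4c3)n2)cc1`, gives 32%. Compound 3, `Fc1ccc(-c2cn3ccnc3c(-c3ccc4ncn(C5CCCCC5)c4c3)n2)cc1`, gives 7.94%, the lowest of the three numbers; its nearest neighbour is compound 2, and compound 1 is furthest. The recorded steps are a number 5.3 percentage points lower from compound 1 to compound 2 (within the scatter), a number 29.4 percentage points lower from compound 1 to compound 3 (beyond the scatter) and a number 24.1 percentage points lower from compound 2 to compound 3 (beyond the scatter).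

The next compound is compound 4, `CC(=O)c1ccc(-c2cn3ccnc3c(-c3ccc4ncn(C5CCCCC5)c4c3)n2)cc1`. Its difference from compound 3 is acetyl in place of fluoro on an aromatic carbon. For the measured compounds named here, two measured steps bear on this. The step of a number 24.1 percentage points lower from compound 2 to compound 3 (beyond the scatter) shows that putting fluoro where formyl stood lowers this assay markedly, and a number 29.4 percentage points lower from compound 1 to compound 3 (beyond the scatter) shows a loss of similar size when fluoro replaces hydrogen. The small step of a number 5.3 percentage points lower from compound 1 to compound 2 (within the scatter) suggests that a carbonyl-bearing group on this ring behaves much like hydrogen. Acetyl resembles formyl in carrying a carbonyl, so removing fluoro in its favour is expected to recover most of the lost inhibition, a step of about a number 22.1 percentage points higher from compound 3 to compound 4 (beyond the scatter). Compound 4 is therefore estimated at 30%, within a range from 12% to 48%.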

Compound 4, a percentage reported as inhibition, at one concentration (the size of the read-out at that concentration, not a potency): 3.02%
For compound 4 the middle estimate is 27 percentage points above the measured one; the measured number lies below the stated range.
By their numbers in this assay, from the lowest: compounds 4 and 3 (each within the scatter of the next); then compounds 2 and 1 (each within the scatter of the next).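

In this assay, acetyl in place of fluoro gives a number 4.9 percentage points lower from compound 3 to compound 4 (within the scatter), so on this aromatic carbon, para to a large group, the change from 4-fluorophenyl to 4-acetylphenyl does not bring back the inhibition seen with hydrogen or formyl. A carbonyl alone therefore does not place a group with formyl here: methyl in place of hydrogen on the carbonyl carbon gives a number 29 percentage points lower from compound 2 to compound 4 (beyond the scatter), and acetyl in place of hydrogen on the aromatic carbon gives a number 34.3 percentage points lower from compound 1 to compound 4 (beyond the scatter). No measurement at hand accounts for this effect of the added methyl.

The compounds shown leave open whether a longer chain on the carbonyl carbon would behave like acetyl or formyl. They also leave open how an amine or a carboxylic acid at this position would compare with hydrogen.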